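This account rests on a few compounds, and the source may have more. Where it says the series, first, only, none or still open, it means among the compounds named here.

In a functional assay on MC-38 cells (Mus musculus) for antiproliferative activity, read by CCK-8 assay, with a stated time of 48 h (a lower number here means a stronger inhibitor, a higher number a weaker inhibitor), compound 1 `COc1ccc(/C=C\c2cc(OC)c(OC)c(OC)c2)cc1OCc1ccc(CN2CCCCC2C(=O)NCCNC(=O)OC(C)(C)C)cc1` gives 1900 nM. Compound 2 `COc1ccc(/C=C\c2cc(OC)c(OC)c(OC)c2)cc1OCc1ccc(CN2CC(C(=O)O)C2)cc1` gives > 10000 nM, and this reading is a limit of the assay, not a number. The next compound, compound 3 `COc1ccc(/C=C\c2cc(OC)c(OC)c(OC)c2)cc1OCc1ccc(CN2CCCCC2C(=O)NCCN)cc1`, departs from compound 2 on a saturated chain carbon bound to an aromatic carbon: 2-((2-aminoethyl)carbamoyl)piperidin-1-yl in place of 3-carboxyazetidin-1-yl on a saturated chain carbon bound to an aromatic carbon. Its reading in this assay is expected to show stronger inhibition, and the expectation leans on compound 1 at 1900 nM. The expected step is an at least 5.5-fold lower number from compound 2 to compound 3 (0.74 log units; beyond the scatter). For compound 3 the estimated value is 1800 nM, with an expected range of 400 nM to 8000 nM.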

Compound 3, half-maximal inhibitory concentration: > 10000 nM
Compound 3 was reported as a limit (the forecaster's own chance of this, stated with the estimate: 12%); at least 5.5-fold (0.74 log units) between middle value and limit.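

Hydrogen in place of tert-butoxycarbonyl on an amine nitrogen gives an at least 5.2-fold higher number from compound 1 to compound 3 (0.72 log units; beyond the scatter) in this assay, so at this nitrogen the tert-butoxycarbonyl group goes with the stronger reading. Compound 3 gives > 10000 nM, which is a limit of the assay and not a number. The step between compound 2 and compound 3 cannot be read, because both sit at the same limit: the limit of > 10000 nM in this assay, at which 2 of the 3 values shown sit.

From the compounds shown here alone, how far either compound lies past that limit stays open. So does whether a smaller acyl group such as acetyl on that amine nitrogen would keep the reading of compound 1.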